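Rigosertib-type styryl sulfones: bromo to methoxy swap

A few compounds are considered here, and "the series" means these few. Any claim that something is new, unique, unknown or untested is made for them only; others in the source may bear on it.

Compound 1 `COc1cc(OC)c(/C=C/S(=O)(=O)Cc2ccc(OC)c([N+](=O)[O-])c2)c(OC)c1` gives 2500 nM in a functional assay on DU-145 cells (Homo sapiens) for cytotoxicity, read by trypan blue exclusion, with a stated time of 96 h; on this read-out higher numbers stand for weaker inhibition and lower numbers for stronger inhibition. Compound 2 `COc1cc(OC)c(/C=C/S(=O)(=O)Cc2ccc(Br)c([N+](=O)[O-])c2)c(OC)c1` gives 25000 nM in this assay. Compound 3 `COC(=O)C(Nc1cc(CS(=O)(=O)/C=C/c2c(OC)cc(OC)cc2OC)ccc1OC)c1ccc(Br)cc1` gives 300 nM in this assay.

Compound 3 has the lowest number of the three measured compounds. The difference between the core of compound 3 and the core of compound 2 is not broken down here. Among the measured compounds shown here, the one measured single change is methoxy in place of bromo on an aromatic carbon, which gave a 10-fold lower number from compound 2 to compound 1 (1.00 log units; beyond the scatter).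

The unmeasured compound 4 `COC(=O)C(Nc1cc(CS(=O)(=O)/C=C/c2c(OC)cc(OC)cc2OC)ccc1OC)c1ccc(OC)cc1` is made from compound 3 by methoxy in place of bromo on an aromatic carbon. This is the same kind of change as that from compound 2 to compound 1, not the same: in compound 2 the place is also ortho to a nitro group, while in compound 3 it is only para to a large group. Because a 10-fold lower number from compound 2 to compound 1 (1.00 log units; beyond the scatter) went beyond the scatter, a lower number is expected for compound 4 in this assay, though with a single precedent in different surroundings the expected step from compound 3 is kept smaller, a 2.0-fold lower number from compound 3 to compound 4 (0.30 log units; within the scatter). The estimate for compound 4 in this assay is 150 nM, expected between 50 nM and 600 nM.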

Compound 4, half-maximal inhibitory concentration: 250 nM
The estimate for compound 4 lay 1.7-fold (0.22 log units) below the measured number, within the range that was stated.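

In this assay, methoxy in place of bromo on the 4-bromophenyl group gives a 1.2-fold lower number from compound 3 to compound 4 (0.08 log units; within the scatter), so no change can be read on this core. The swap does not carry over in size from one core to the other: the same change on two cores in this assay, a 10-fold lower number (1.00 log units; beyond the scatter) from compound 2 to compound 1 and a 1.2-fold lower number (0.08 log units; within the scatter) from compound 3 to compound 4, 8.3-fold (0.92 log units) apart, beyond the scatter of two such steps. This shows that the step seen on the core of compound 1 cannot be taken as a rule for the series, but it does not show what sets the two steps apart, and two pairs on cores that differ in more than one feature give no general rule for how far the change transfers.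

On these data alone, it remains open whether the larger step is tied to the nitro group, which the core of compound 3 does not carry. Also open, as far as these compounds go, is how an amine or a hydroxyl in place of the bromo, or a carboxylic acid in place of the methyl ester, would stand against compound 3 on the shared core.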